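Swapping a trifluoromethyl-bearing aryl for a dimethyl-bearing aryl

The source may report more compounds than this note shows. Statements on the series, on what has been measured and on what is new or still open speak of the compounds shown alone.

Of the compounds shown here, three sharing one core have been measured in an assay on HEK293 cells for inhibition of Voltage-dependent T-type calcium channel subunit alpha-1G (Homo sapiens), read by patch clamp; on this read-out higher numbers stand for weaker inhibition and lower numbers for stronger inhibition. Compound 1 `CCCc1nc(-c2ccccc2)c(CNCCN2CCN(c3ccc(Cl)cc3)CC2)o1` gives 2820 nM. Compound 2 `CCCc1nc(-c2ccccc2)c(CNCCN2CCN(c3ccccc3)CC2)o1`, which carries hydrogen in place of chloro on an aromatic carbon, gives 10300 nM; that step, a 3.7-fold higher number from compound 1 to compound 2 (0.56 log units; beyond the scatter), shows that stripping a substituent from the aryl ring weakens inhibition modestly. Compound 3 `CCCc1nc(-c2ccccc2)c(CNCCCN2CCN(c3cccc(C(F)(F)F)c3)CC2)o1` gives 650 nM, the lowest of the three numbers, so it stands as the strongest inhibitor here, with compound 1 nearest and compound 2 furthest.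

Compound 4 `CCCc1nc(-c2ccccc2)c(CNCCCN2CCN(c3ccc(C)c(C)c3)CC2)o1` has not yet been measured. It differs from compound 3 in one place: 3,4-dimethylphenyl in place of 3-(trifluoromethyl)phenyl on an amine nitrogen in a ring. Going by the values given here, the only measured step touching the aryl ring is the one from compound 1 to compound 2, and it concerns a loss rather than an exchange of substituents, so it bears only loosely on this change. Since compound 4 keeps the ring substituted, a step smaller than that one is expected, tending toward a higher number. The expected step is a 2.0-fold higher number from compound 3 to compound 4 (0.30 log units; within the scatter), and compound 4 is estimated at 1300 nM, within a range from 400 nM to 4000 nM.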

Compound 4, half-maximal inhibitory concentration: 3020 nM
For compound 4 the middle estimate is 2.3-fold (0.37 log units) below the measured one; the measured number falls inside the stated range.
By their numbers in this assay, from the lowest: compound 3; then compounds 1 and 4 (each within the scatter of the next); then compound 2.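

Going by these compounds alone, until now, the only change seen on the aryl ring was the loss of a chloro group, whereas this step exchanges one substituted ring for another. In this assay, 3,4-dimethylphenyl in place of 3-(trifluoromethyl)phenyl gives a 4.6-fold higher number from compound 3 to compound 4 (0.67 log units; beyond the scatter), so having a substituted ring on this amine nitrogen does not by itself keep the number as low as that of compound 3: which groups the ring carries matters too. The group that leaves has 10 heavy atoms, including 3 fluorine, and the group that enters has 8 heavy atoms, all carbon, while both have 0 hydrogen-bond donors, 0 hydrogen-bond acceptors and no net charge; no measurement here explains why the number changes.

This swap alters both the identity of the substituents and how many the ring carries, so the compounds shown cannot tell whether the step comes from losing the trifluoromethyl group or from gaining the two methyl groups. As far as these compounds go, a 3-methylphenyl group on the same nitrogen would help separate those two changes, and it remains open whether a 3-chlorophenyl group would behave more like 3-(trifluoromethyl)phenyl.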